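This account rests on a few compounds, and the source may have more. Where it says the series, first, only, none or still open, it means among the compounds named here.

Measured in a functional assay on IMR-32 cells (Homo sapiens) for antiproliferative activity, read by MTT assay; a lower number here means a stronger inhibitor, a higher number a weaker inhibitor:
- compound 1 `CC1(C)CCc2cc(C(=O)/C=C/c3ccc(OCc4cn(-c5ccc(Br)cc5)nn4)cc3)c(O)cc2O1`: 69400 nM
- compound 2 `CCc1ccccc1-n1cc(COc2ccc(/C=C/C(=O)c3cc4c(cc3O)OC(C)(C)CC4)cc2)nn1`: "not active" (no number reported)

Within the data shown here, compound 2 has no number that could place it on the scale, as the only result for compound 2 is "not active" (no number reported). Compound 3 `Cc1ccc(-n2cc(COc3ccc(/C=C/C(=O)c4cc5c(cc4O)OC(C)(C)CC5)cc3)nn2)cc1Br` has not yet been measured. The structural change is 3-bromo-4-methylphenyl in place of 2-ethylphenyl on an aromatic nitrogen, which puts 3-bromo-4-methylphenyl in place of 2-ethylphenyl on an aromatic nitrogen.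

Without a number for compound 2, the size of this step in this assay cannot be worked out, so any expectation is tentative. The nearest guide is compound 1, which also carries a bromine in this group and gives 69400 nM. A small move towards stronger inhibition is expected, to a weak result near that of compound 1, although another result without a number would be no surprise. For compound 3 the estimated value is 50000 nM, with an expected range from 15000 nM to 130000 nM.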

Compound 3, half-maximal inhibitory concentration: "not active" (no number reported)
Compound 3: no number reported; the estimate stays without a comparison.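

In this assay, compound 2 and compound 3 are both reported as not active, without a number, so no step can be read between them. Going by these compounds, whether 3-bromo-4-methylphenyl or 2-ethylphenyl gives the stronger inhibition stays open. No evidence bears on this result.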